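This account rests on a few compounds, and the source may have more. Where it says the series, first, only, none or still open, it means among the compounds named here.

Of the compounds shown here, two that share one core have been tested in a functional assay on HeLa cells (Homo sapiens) for cytotoxicity, read by CCK-8 assay; a higher number here means a weaker inhibitor, a lower number a stronger inhibitor. Compound 1 `Oc1cccc(-c2cc(-c3ccccn3)cc(-c3cccc(O)c3)n2)c1` gives 6500 nM in this assay. Compound 2 `Oc1ccc(-c2cc(-c3ccccn3)cc(-c3cccc(O)c3)n2)cc1` carries a 4-hydroxyphenyl group where compound 1 carries a 3-hydroxyphenyl group. In this assay compound 2 gives 1930 nM. That single change brought a 3.4-fold lower number from compound 1 to compound 2 (0.53 log units; beyond the scatter), so compound 2 holds the lower of the two numbers, and its gap to compound 1 lies beyond the scatter. Compound 3 `Oc1ccc(-c2cc(-c3cccnc3)cc(-c3cccc(O)c3)n2)cc1` has not yet been measured. It differs from compound 2 in one place: pyridin-3-yl in place of pyridin-2-yl on an aromatic carbon. Within the data shown here, the only measured step concerns the hydroxyphenyl group, not the pyridinyl group, so no measured step bears on this change. In the absence of such guidance the change is expected to bring no step beyond the scatter: a 1.3-fold higher number from compound 2 to compound 3 (0.11 log units; within the scatter). Compound 3 is therefore estimated at 2500 nM, within a range from 800 nM to 8000 nM.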

Compound 3, half-maximal inhibitory concentration: > 50000 nM
Compound 3: no number, only a limit (the forecaster's own chance of this, stated with the estimate: 5%); middle value at least 20-fold (1.30 log units) away from the limit.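

Swapping pyridin-2-yl for pyridin-3-yl keeps the same atoms and the same counts of donors and acceptors, yet in this assay it brought an at least 25-fold higher number from compound 2 to compound 3 (1.41 log units; beyond the scatter). The figure for compound 3 is a limit of the assay and not a number: the limit of > 50000 nM in this assay, at which 1 of the 3 values shown sits. This shows that the position opposite the ring nitrogen of the shared core is highly sensitive to where the pyridine nitrogen sits, and this large step exceeds the modest one seen earlier, a 3.4-fold lower number from compound 1 to compound 2 (0.53 log units; beyond the scatter).

From the compounds shown here alone, it remains open whether a phenyl group, with no ring nitrogen, or a pyridin-4-yl group at this position would stay close to compound 2. Also open, going by these compounds, is whether the same swap would have as large an effect on compound 1, which carries two 3-hydroxyphenyl groups.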